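The source may hold more compounds than are shown below. What is called first, only, known or untested is meant among the compounds shown, and "the series" means these compounds.

Three compounds share one core and differ in the group on an oxygen on an aromatic ring, and all three were tested in a functional assay on K562 cells (Homo sapiens) for cytotoxicity, read by MTT assay; a higher number here means a weaker inhibitor, a lower number a stronger inhibitor. Compound 1 `C=CCOc1cc(/C=C/C(=O)c2ccc(OC)c3c2OC(C)(C)C=C3)ccc1OC`, carrying allyl there, reads > 10000 nM, which is a limit of the assay and not a number. Compound 2 `COc1ccc(/C=C/C(=O)c2ccc(OC)c3c2OC(C)(C)C=C3)cc1OCCCN(C)C`, carrying 3-(dimethylamino)propyl, gives 2920 nM. Compound 3 `CCC(=O)Oc1cc(/C=C/C(=O)c2ccc(OC)c3c2OC(C)(C)C=C3)ccc1OC`, carrying propanoyl, gives 160 nM, the lowest number of the set and so the strongest inhibitor of the three.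

The next step leads to compound 4 `COc1ccc(/C=C/C(=O)c2ccc(OC)c3c2OC(C)(C)C=C3)cc1OC(=O)C(C)C`, where propanoyl becomes isopropylcarbonyl: methyl in place of hydrogen on a saturated chain carbon bound to a carbonyl carbon and a saturated chain carbon. Among the measured compounds shown here, two measured steps bear on this oxygen: an at least 62-fold lower number from compound 1 to compound 3 (1.79 log units; beyond the scatter) and an 18-fold lower number from compound 2 to compound 3 (1.26 log units; beyond the scatter). Both are large, so the group on this oxygen can shift the number in this assay a long way. Each of those steps replaces the whole group, however, whereas compound 4 keeps the carbonyl of compound 3 and adds only a methyl in place of hydrogen on a saturated chain carbon. For the measured compounds named here, no measured step tests so small a change, so no step beyond the scatter is expected, though this is an uncertain call. The estimated change is a 1.3-fold higher number from compound 3 to compound 4 (0.10 log units; within the scatter). For compound 4 the expected value is 200 nM, with an estimated range of 70 nM to 600 nM.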

Compound 4, half-maximal inhibitory concentration: 570 nM
The estimate for compound 4 lay 2.9-fold (0.45 log units) below the measured number; low and high end bracket the measured number.
By their numbers in this assay, from the lowest: compound 3; then compound 4; then compound 2. At a limit, above all of these: compound 1.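

In this assay, among the compounds shown here, the group on this oxygen had so far changed only as a whole, and this is the first step to touch a single spot on the saturated chain carbon bound to a carbonyl carbon and a saturated chain carbon: one methyl in place of hydrogen gives a 3.6-fold higher number from compound 3 to compound 4 (0.55 log units; beyond the scatter), so even so small a change can count here. The carbonyl-bearing group of compound 4 still stands ahead of 3-(dimethylamino)propyl, with a 5.1-fold lower number from compound 2 to compound 4 (0.71 log units; beyond the scatter), which means that the order of compound 3, then compound 4, then compound 2 holds despite the added methyl. Against allyl the step is an at least 17-fold lower number from compound 1 to compound 4 (1.24 log units; beyond the scatter), but compound 1 gives only a limit of the assay and not a number: the limit of > 10000 nM in this assay, at which 1 of the 4 values shown sits.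

For the compounds shown here, only two groups of this carbonyl type appear, so it stays open whether a longer straight chain such as butanoyl would sit nearer propanoyl or isopropylcarbonyl, and whether a tert-butylcarbonyl group would take the number further up. Also open, on these data alone, is how a group joining both features, such as a carbonyl chain ending in a dimethylamine, would read.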